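A few compounds are considered here, and "the series" means these few. Any claim that something is new, unique, unknown or untested is made for them only; others in the source may bear on it.

Measured so far in a functional assay on CHO cells for agonist activity at adenosine receptor A1 (Homo sapiens), read by fluorescence and ERK phosphorylation, with stated times of 30 min and 1.5 h, tested at 10 uM; on this read-out higher numbers stand for a stronger effect at the one concentration tested and lower numbers for a weaker effect:
compound 1 `Nc1scc(-c2ccccc2F)c1C(=O)c1ccccc1` gives 68%
compound 2 `Nc1scc(-c2ccc3ccccc3c2)c1C(=O)c1ccccc1` gives 73%
compound 3 `Nc1scc(-c2ccccc2F)c1C(=O)c1ccc(Cl)cc1` gives 87%

Compound 3 differs from compound 1 by chloro in place of hydrogen on an aromatic carbon, and the step in this assay is a number 19 percentage points higher from compound 1 to compound 3 (beyond the scatter). The difference between the cores of compound 1 and compound 2 is not broken down here; their values in this assay lie within the scatter of each other. Compound 4 `Nc1scc(-c2ccc3ccccc3c2)c1C(=O)c1ccc(Cl)cc1`, not yet measured, differs from compound 2 by chloro in place of hydrogen on an aromatic carbon, which is the same change as from compound 1 to compound 3, at the same kind of place. Within the data shown here, for compound 4 the expected step in this assay is a number 13 percentage points higher from compound 2 to compound 4 (beyond the scatter), resting on the single earlier example a number 19 percentage points higher from compound 1 to compound 3 (beyond the scatter) and on the read-out being a percentage with limited room upward. Compound 4 is therefore estimated at 86%, between 74% and 97%.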

Compound 4, a percentage reported as activity, at one concentration (the size of the read-out at that concentration, not a potency): 67%
The estimate for compound 4 lay 19 percentage points above the measured number; the measured number lies below the stated range.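

Chloro in place of hydrogen on an aromatic carbon does not carry over unchanged between these cores in this assay, where the new step is a number 6 percentage points lower from compound 2 to compound 4 (within the scatter). Set beside the earlier step, the two results differ: the same change on two cores in this assay, a number 19 percentage points higher (beyond the scatter) from compound 1 to compound 3 and a number 6 percentage points lower (within the scatter) from compound 2 to compound 4, 25 percentage points apart, beyond the scatter of two such steps. The step seen on the core of compound 1 therefore cannot be assumed on the core of compound 2, but two pairs do not show which feature of the cores accounts for the gap or how the change would behave on a further core.

Open, on these data alone, is whether a different group at the same place, such as methoxy or an amine, would follow either core's result. Also open, as far as these compounds go, is whether these single-concentration readings would hold across a range of concentrations.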